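The source may report more compounds than this note shows. Statements on the series, on what has been measured and on what is new or still open speak of the compounds shown alone.

Compound 1 `OC[C@H]1O[C@@H](n2cnc3c(NCc4ccco4)ncnc32)[C@H](O)[C@@H]1O` gives 36300 nM in an assay on isolated protein for binding affinity to Equilibrative nucleoside transporter 1 (Homo sapiens); on this read-out higher numbers stand for weaker inhibition and lower numbers for stronger inhibition. Compound 2 `OC[C@H]1O[C@@H](n2cnc3c(CSc4ccccc4I)ncnc32)[C@H](O)[C@@H]1O` gives 282 nM in this assay, and compound 3 `OC[C@H]1O[C@@H](n2cnc3c(CSc4ccc(Cl)c(Cl)c4)ncnc32)[C@H](O)[C@@H]1O` gives 224 nM in this assay. The step of a 130-fold lower number from compound 1 to compound 2 (2.11 log units; beyond the scatter) is large, whereas the step of a 1.3-fold lower number from compound 2 to compound 3 (0.10 log units; within the scatter) stays within the scatter. Compound 3 therefore holds the lowest of the three numbers, but its value and that of compound 2 cannot be told apart, while compound 1 stands far higher.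

Compound 4 `OC[C@H]1O[C@@H](n2cnc3c(CSc4cccc(I)c4)ncnc32)[C@H](O)[C@@H]1O` has not yet been measured. It differs from compound 3 by 3-iodophenyl in place of 3,4-dichlorophenyl on a sulfur. Within the data shown here, the only measured step of the same kind, an exchange of one halogen-bearing phenyl for another on the sulfur, is a 1.3-fold lower number from compound 2 to compound 3 (0.10 log units; within the scatter), which stayed within the scatter. The step of a 130-fold lower number from compound 1 to compound 2 (2.11 log units; beyond the scatter) alters a different part of the molecule and offers no guidance here. Compound 4 is therefore expected to move by a 1.3-fold higher number from compound 3 to compound 4 (0.13 log units; within the scatter), that is, no step beyond the scatter. Compound 4 is estimated at 300 nM in this assay, with a range from 100 nM to 900 nM.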

Compound 4, half-maximal inhibitory concentration: 245 nM
Compound 4: middle estimate off by 1.2-fold (0.09 log units), on the high side; the measured number falls inside the stated range.
By their numbers in this assay, from the lowest: compounds 3, 4 and 2 (each within the scatter of the next); then compound 1.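

In this assay, the exchange of 3,4-dichlorophenyl for 3-iodophenyl on the sulfur gives a 1.1-fold higher number from compound 3 to compound 4 (0.04 log units; within the scatter) and stays within the scatter, as does the exchange of 2-iodophenyl for 3-iodophenyl, with a 1.2-fold lower number from compound 2 to compound 4 (0.06 log units; within the scatter). Among these compounds, this is the first comparison of the same halogen at two places on the phenyl, and for these iodophenyl compounds the place makes no measurable difference, while a 150-fold lower number from compound 1 to compound 4 (2.17 log units; beyond the scatter) shows that a third halogen-bearing phenyl on the sulfur keeps the large gap to compound 1. Nothing available explains why these exchanges on the sulfur leave the number within the scatter.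

As far as these compounds go, whether this tolerance extends beyond halogens, for example to an amine or a carboxylic acid on the phenyl, remains open. So does the effect of a longer chain between sulfur and phenyl, and the step from compound 1 cannot separate the contributions of the sulfur-bearing chain and the ring.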